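Bromomethyl in place of ethoxycarbonyl: notes on compound 3

A few compounds are considered here, and "the series" means these few. Any claim that something is new, unique, unknown or untested is made for them only; others in the source may bear on it.

In a functional assay on SK-BR-3 cells (Homo sapiens) for cytotoxicity, read by MTT assay, with a stated time of 72 h (a lower number here means that less compound is needed, a higher number that more compound is needed for the effect), compound 1 (`CCOC(=O)c1c(C)coc1-c1ccc2c(CC)cccc2c1OC`) gives 2.5 ug/mL, and compound 2 (`CCOc1c(-c2occ(C)c2C(=O)OC)ccc2c(CC)cccc12`) gives 1.9 ug/mL. For the measured compounds named here, these two values lie within the scatter of each other, so compound 1 stands level with the only other measured number. Compound 3 (`CCc1cccc2c(OC)c(-c3occ(C)c3CBr)ccc12`) keeps the core of compound 1 and carries bromomethyl in place of ethoxycarbonyl on an aromatic carbon. Going by the values given here, no measured pair differs in one place, so no measured step guides this change, and the expectation rests on compound 1 at 2.5 ug/mL alone. A small move toward a lower number in this assay is expected, hardly beyond the scatter and with wide uncertainty. The estimated step is a 1.6-fold lower number from compound 1 to compound 3 (0.19 log units; within the scatter). For compound 3 the expected value is 1.6 ug/mL, with an estimated range of 0.4 ug/mL to 5 ug/mL.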

Compound 3, concentration for half-maximal effect: > 10 ug/mL
Compound 3 gave a limit, no number (the forecaster's own chance of this, stated with the estimate: 5%); at least 6.2-fold (0.79 log units) between middle value and limit.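

Bromomethyl in place of ethoxycarbonyl on this aromatic carbon of the five-membered ring is the first one-place change in the series, and it gives an at least 4.0-fold higher number from compound 1 to compound 3 (0.60 log units; beyond the scatter) in this assay. For the compounds shown here, this shows that the position is not indifferent to the group it carries, something the earlier compounds could not show. For compound 3 the reading is a limit and not a number: the limit of > 10 ug/mL in this assay, at which 1 of the 3 values shown sits.

The step therefore gives a direction, while its full size stays unread, and a single replacement cannot separate the loss of ethoxycarbonyl from the arrival of bromomethyl. A carboxylic acid, a primary amide or a hydroxymethyl group on the same carbon would bear on that open question.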